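A Methyl on the Fused Ring Lowers Paw Edema Inhibition

The source may hold more compounds than are shown below. What is called first, only, known or untested is meant among the compounds shown, and "the series" means these compounds.

Three compounds built on a shared core were tested in a functional assay on the whole organism with Rattus norvegicus as the target, read by paw edema, with a stated time of 3 h, at a dose of 100 mg/kg by the oral route; a higher number here means more inhibition at the dose given (going by the name of the read-out), a lower number less inhibition. Compound 1 `Cc1ccc(-c2nc3ccccc3[nH]2)nc1` gives 19%. Compound 3 `Cc1ccc(-c2nc3cc(C)ccc3[nH]2)nc1` gives 7%; it differs from compound 1 by methyl in place of hydrogen on an aromatic carbon and the result is a number 12 percentage points lower from compound 1 to compound 3 (beyond the scatter). Compound 2 `Clc1cccc(-c2nc3ccccc3[nH]2)n1` gives 30%, the highest of the three numbers; how the core of compound 2 differs from the core of compound 1 is not broken down here. Compound 4 `Cc1ccc2[nH]c(-c3cccc(Cl)n3)nc2c1` has not yet been measured. It differs from compound 2 by methyl in place of hydrogen on an aromatic carbon, the same change, at the same place, as that from compound 1 to compound 3. The expected step is a number 12 percentage points lower from compound 2 to compound 4 (beyond the scatter), resting on the fact that this change gave a number 12 percentage points lower from compound 1 to compound 3 (beyond the scatter) in the measured pair. Compound 4 is therefore estimated at 18%, expected to lie between 5% and 32%.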

Compound 4, a percentage reported as inhibition, in the whole organism at one dose (the size of the read-out at that dose, not a potency): 36%
For compound 4 the middle estimate is 18 percentage points below the measured one; the whole stated range lies below it.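

On the core of compound 2, methyl in place of hydrogen gives a number 6 percentage points higher from compound 2 to compound 4 (within the scatter), so the drop seen on the core of compound 1 does not repeat there. In this assay, this change therefore does not carry from one core to the other as a fixed step: the same change on two cores in this assay, a number 12 percentage points lower (beyond the scatter) from compound 1 to compound 3 and a number 6 percentage points higher (within the scatter) from compound 2 to compound 4, 18 percentage points apart, beyond the scatter of two such steps. Among the compounds shown here, with only one pair on each core, this does not show why the two cores part ways, nor how the change would behave on any further core.

The compounds shown leave open how an amine or a carboxylic acid at this same place would behave on either core. They also leave open whether methyl on a third core would follow the pair ending in compound 3 or the pair ending in compound 4.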